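The source may hold more compounds than are shown below. What is called first, only, known or untested is meant among the compounds shown, and "the series" means these compounds.

Working notes on the series.

In a functional assay on UACC-62 cells (Homo sapiens) for inhibition, read by sulforhodamine B assay, with a stated time of 48 h (a higher number here means a weaker inhibitor of growth, a lower number a stronger inhibitor of growth), compound 1, `COc1ccc(-c2cc(/C=C/C(=O)c3ccc(OC)c(OC)c3)[nH]n2)cc1`, gives 1650 nM. Compound 2, `COc1cc(-c2cc(/C=C/C(=O)c3ccc(Cl)c(Cl)c3)[nH]n2)cc(OC)c1OC`, gives 18800 nM in this assay and so stands at the highest of the two numbers recorded; its nearest neighbour on the numbers is compound 1, whose value is well beyond the scatter of it. The two differ at more than one place, so what their values show is a gap between them and nothing finer.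

Compound 3, `COc1cc(-c2cc(/C=C/C(=O)c3ccc(F)c(F)c3)[nH]n2)cc(OC)c1OC`, has not yet been measured in this assay. It differs from compound 2 as follows: 3,4-difluorophenyl in place of 3,4-dichlorophenyl on a carbonyl carbon. Among the compounds with values here, no step between measured compounds exchanges one halogen for another on this carbonyl-bound ring, so there is nothing from which to read the size of the step. The expectation is a step from compound 2 to compound 3 of a 1.2-fold higher number from compound 2 to compound 3 (0.07 log units; within the scatter), that is, no change beyond the scatter, with weaker growth inhibition somewhat more likely than stronger. For compound 3 the estimated value in this assay is 22000 nM, within the range 7000 nM to 65000 nM.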

Compound 3, concentration for 50% growth inhibition: 2380 nM
Compound 3: the middle estimate sits 9.2-fold (0.97 log units) above what was measured; the whole stated range lies above it.
By their numbers in this assay, from the lowest: compounds 1 and 3 (each within the scatter of the next); then compound 2.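

Within the data shown here, with the rest of the structure unchanged, 3,4-difluorophenyl in place of 3,4-dichlorophenyl on a carbonyl carbon gives a 7.9-fold lower number from compound 2 to compound 3 (0.90 log units; beyond the scatter) in this assay, so this is the first step that can be read at one place, and it shows that the exchange of halogen on this ring is not neutral for growth inhibition. The two groups match in heavy-atom count, in their single six-membered aromatic ring of carbon only, and in hydrogen-bond donors and acceptors, so those counts do not separate them, and the step goes with the change from chlorine to fluorine alone. No measurement at hand bears on the reason for this step, which stands as a single observation from one pair.

Still open, as far as these compounds go, is where an unsubstituted phenyl, a 3,4-dibromophenyl or a phenyl bearing a trifluoromethyl group would stand on this carbonyl carbon relative to the two halogenated rings. Also open, from the compounds shown here alone, is whether the same exchange of 3,4-dichlorophenyl for 3,4-difluorophenyl gives a step of similar size with the other aryl group of compound 1 in place.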